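Swapping the aryl on the carbonyl of a pyrazole chalcone

The source may hold more compounds than are shown below. What is called first, only, known or untested is meant among the compounds shown, and "the series" means these compounds.

Measured so far:
compound 1 `COc1cc(-c2cc(/C=C/C(=O)c3ccc(Cl)c(Cl)c3)[nH]n2)cc(OC)c1OC` — 54%
compound 2 `COc1ccc(C(=O)/C=C/c2cc(-c3cc(OC)c(OC)c(OC)c3)n[nH]2)cc1` — 94%

In a functional assay on COLO 205 cells (Homo sapiens) for cytotoxicity, read by sulforhodamine B assay, with a stated time of 48 h, tested at 1 uM (a higher number here means a weaker effect of the compound at the concentration tested, a lower number a stronger effect), compound 2 gives 94%, the highest of the two numbers recorded so far; its nearest neighbour is compound 1, which gives 54%. Going by the values given here, the only measured step, a number 40 percentage points higher from compound 1 to compound 2 (beyond the scatter), is the replacement of 3,4-dichlorophenyl by 4-methoxyphenyl on the carbonyl carbon.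

Compound 3 `COc1cc(-c2cc(/C=C/C(=O)c3ccc(F)c(F)c3)[nH]n2)cc(OC)c1OC` has not yet been measured. It differs from compound 2 by 3,4-difluorophenyl in place of 4-methoxyphenyl on a carbonyl carbon. The change runs opposite to the measured step, since it again puts a dihalophenyl in the place of 4-methoxyphenyl, so the step from compound 1 to compound 2 bears on it directly. Given that step, the number for compound 3 is expected to fall beyond the scatter, by about a number 29 percentage points lower from compound 2 to compound 3 (beyond the scatter). Compound 3 is therefore estimated at 65%, within a range of 45% to 90%.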

Compound 3, a percentage reported as activity, at one concentration (the size of the read-out at that concentration, not a potency): 92%
For compound 3 the middle estimate is 27 percentage points below the measured one; measured number outside the range, above it.
By their numbers in this assay, from the lowest: compound 1; then compounds 3 and 2 (each within the scatter of the next).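

In this assay, the change to 3,4-difluorophenyl on the carbonyl carbon gives a number 2 percentage points lower from compound 2 to compound 3 (within the scatter), so this dihalophenyl group cannot be told apart from 4-methoxyphenyl here. Set against 3,4-dichlorophenyl, the same group gives a number 38 percentage points higher from compound 1 to compound 3 (beyond the scatter), which shows that a dihalophenyl at this place does not in itself bring the stronger effect: of the three groups, only 3,4-dichlorophenyl, in compound 1, stands apart. Nothing available explains why the dichloro and difluoro groups part ways.

The compounds shown leave open whether a phenyl carrying a single chlorine would keep the effect of compound 1. They also leave open whether a dibromophenyl group on the carbonyl carbon would match it.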